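Aryl variation on the saturated ring carbon

The source may report more compounds than this note shows. Statements on the series, on what has been measured and on what is new or still open speak of the compounds shown alone.

Going by the values given here, compound 2 `Cc1cccc(NC(=O)CN2CCC(c3cccc(C#N)n3)CC2)c1` gives the lower of the two numbers so far in a functional assay on HEK293 cells for agonist activity at D(4) dopamine receptor (Homo sapiens), read by FLIPR (a higher number here means that more compound is needed for the effect, a lower number that less compound is needed), at 36 nM; compound 1 `Cc1cccc(NC(=O)CN2CCC(c3ccc(O)cc3)CC2)c1` gives 70 nM, and the gap is within the scatter (a 1.9-fold lower number from compound 1 to compound 2 (0.29 log units; within the scatter)). Compound 3 `Cc1cccc(NC(=O)CN2CCC(c3ccccc3)CC2)c1` carries the next change at that same position: phenyl in place of 6-cyanopyridin-2-yl on a saturated ring carbon. Among the compounds with values here, the only measured step that bears on it is a 1.9-fold lower number from compound 1 to compound 2 (0.29 log units; within the scatter), an earlier exchange of the aryl group on the same saturated ring carbon that stayed within the scatter. No movement beyond the scatter is therefore expected, a 1.4-fold higher number from compound 2 to compound 3 (0.14 log units; within the scatter). Compound 3 is estimated at 50 nM, range 20 nM to 150 nM.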

Compound 3, half-maximal effective concentration: 170 nM
The estimate for compound 3 lay 3.4-fold (0.53 log units) below the measured number; the measured number lies above the stated range.
By their numbers in this assay, from the lowest: compounds 2 and 1 (each within the scatter of the next); then compound 3.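

In this assay the aryl group on this saturated ring carbon moves the number beyond the scatter, which the earlier exchange did not show: phenyl in place of 6-cyanopyridin-2-yl gives a modest rise (a 4.7-fold higher number from compound 2 to compound 3 (0.67 log units; beyond the scatter)), and hydrogen in place of hydroxy on an aromatic carbon gives another (a 2.4-fold higher number from compound 1 to compound 3 (0.39 log units; beyond the scatter)). Both substituted aryl groups therefore give lower numbers than unsubstituted phenyl. Nothing available explains either step.

As far as these compounds go, whether a nitrile on phenyl, or a pyridine ring without the nitrile, would match compound 2 remains open. So does the outcome with an amine or a carboxylic acid on the phenyl.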